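Shortening the ester chain of a cytidine lipid ester

The compounds below may be only part of what the source reports. "The series", "measured", "known", "first", "only" and "open" are said of these compounds alone.

The study compares cytidine esters carrying long fatty chains. Within the data shown here, in a functional assay on HeLa cells (Homo sapiens) for cytotoxicity, read by cell counting, with a stated time of 48 h (on this read-out higher numbers stand for an effect only at larger amounts of compound and lower numbers for an effect already at smaller amounts), compound 1 `CCCCCCCCCCCC(=O)O[C@H]1[C@H](O)[C@H](n2ccc(N)nc2=O)O[C@@H]1CO` gives 0.08 ug/mL, the lowest of the two numbers known so far. Compound 2 `CCCCCCCCCCCCCC(=O)OC[C@H]1O[C@@H](n2ccc(N)nc2=O)[C@@H](O)[C@@H]1OC(=O)CCCCCCCCCCCCC` gives 1.4 ug/mL in this assay, a gap beyond the scatter. Compound 3 `CCCCCCCCCCC(=O)O[C@H]1[C@H](O)[C@H](n2ccc(N)nc2=O)O[C@@H]1CO` is not yet measured; it differs from compound 1 by hydrogen in place of methyl on a saturated chain carbon, ten or more bonds along the chain from a carbonyl carbon. Among the measured compounds shown here, with no comparable step among the measured pair, the step of a 1.3-fold higher number from compound 1 to compound 3 (0.10 log units; within the scatter) is expected to be small, none beyond the scatter. For compound 3 the estimate is 0.1 ug/mL, within 0.04 ug/mL to 0.3 ug/mL.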

Compound 3, concentration for half-maximal effect: 0.04 ug/mL
Estimate against measurement, compound 3: 2.5-fold (0.40 log units) above; measured number inside the range.
By their numbers in this assay, from the lowest: compounds 3 and 1 (each within the scatter of the next); then compound 2.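

In this assay, among these compounds, the step is a 2.0-fold lower number from compound 1 to compound 3 (0.30 log units; within the scatter), the first direct reading of hydrogen in place of methyl at this place on the chain. At this saturated chain carbon, this change does not separate the two compounds beyond the scatter. No measurement at hand gives a reason for this. The compounds shown leave open whether a much shorter chain, a longer chain, or an amine or carboxylic acid at this place would also stay within the scatter.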